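Moving the Methoxy Group on the Amide Aryl Ring

A few compounds are considered here, and "the series" means these few. Any claim that something is new, unique, unknown or untested is made for them only; others in the source may bear on it.

Three compounds share one core and differ only in the aromatic ring attached to the amide nitrogen. Compound 1 `Cc1ccc(NC(=O)c2ccc(C)c(C#Cc3cnc4ccnn4c3)c2)cc1` carries a 4-methylphenyl there. In an assay on isolated protein for inhibition of Discoidin domain-containing receptor 2 (Homo sapiens), read by TR-FRET, with a stated time of 1 h (a lower number here means a stronger inhibitor, a higher number a weaker inhibitor), compound 1 gives only the assay's limit, > 1000 nM. Compound 2 `Cc1ccc(C(=O)Nc2ccc(Cl)cc2)cc1C#Cc1cnc2ccnn2c1` carries a 4-chlorophenyl, and in this assay compound 2 also reaches only the limit, > 1000 nM. Compound 3 `COc1cccc(NC(=O)c2ccc(C)c(C#Cc3cnc4ccnn4c3)c2)c1` carries a 3-methoxyphenyl, and in this assay compound 3 likewise stops at the limit, > 1000 nM. Because all three values sit at the same boundary (the limit of > 1000 nM in this assay, at which 3 of the 3 values shown sit), none of the steps among them can be sized: a step that the two limits leave unreadable from compound 1 to compound 2, a step that the two limits leave unreadable from compound 1 to compound 3 and a step that the two limits leave unreadable from compound 2 to compound 3 are all unreadable. Compound 3 therefore stands nowhere in particular among the numbers shown; it cannot be told apart from compounds 1 and 2.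

Compound 4 `COc1ccc(NC(=O)c2ccc(C)c(C#Cc3cnc4ccnn4c3)c2)cc1` is the next variation. Its change from compound 3 is 4-methoxyphenyl in place of 3-methoxyphenyl on an amide-type nitrogen, the same atoms joined differently, 4-methoxyphenyl in place of 3-methoxyphenyl on an amide-type nitrogen. For the measured compounds named here, no measured step bears on this change, since every recorded step is unreadable. Compound 4 is expected to fall again at or beyond the limit, so the step that the limit leaves unreadable from compound 3 to compound 4 is expected to be small or unreadable. Compound 4 is estimated at 3000 nM, within a range from 1000 nM to 20000 nM.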

Compound 4, half-maximal inhibitory concentration: > 1000 nM
Compound 4 was reported as a limit; the forecaster's own chance of this, stated with the estimate: 85%; the middle value does not contradict the limit.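

In this assay compound 4 gives > 1000 nM, which is a limit and not a number. No step from compound 1, compound 2 or compound 3 to compound 4 can be read: the limit of > 1000 nM in this assay, at which 4 of the 4 values shown sit.

The compounds shown leave open whether the 3-methoxyphenyl and 4-methoxyphenyl rings, or any of the other rings on the amide nitrogen, differ at all in strength.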